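Acylation of the ring nitrogen of compound 1

The compounds below may be only part of what the source reports. "The series", "measured", "known", "first", "only" and "open" are said of these compounds alone.

The measured compounds and their readings:

compound 1 `COc1ccc(C2=NNC(c3ccco3)C2)cc1OC`: 45%
compound 2 `COc1ccc(C2CC(c3ccc(OC)c(OC)c3)=NN2)c(OC)c1`: 38%
compound 3 `COc1ccc(C2=NNC(c3c(Cl)cccc3Cl)C2)cc1OC`: 26%

Of the compounds shown here, three built on the shared core have been tested in a functional assay on the whole organism (strain albino) for inhibition, with Rattus norvegicus as the target, read by paw edema, with stated times of 30 min and 1 h, at a dose of 100 mg/kg by the oral route; a lower number here means less inhibition, a higher number more inhibition at the dose given (going by the name of the read-out). Compound 1 `COc1ccc(C2=NNC(c3ccco3)C2)cc1OC` gives the highest of the three numbers, 45%. Compound 2 lies nearest to it, lower by a margin that is within the scatter, so no order between compound 1 and compound 2 can be read from these two numbers. Compound 3 lies furthest, lower by a margin that is beyond the scatter.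

Compound 4 `COc1ccc(C2=NN(C(=O)CO[N+](=O)[O-])C(c3ccco3)C2)cc1OC` is not yet measured. It differs from compound 1 in one place: ((nitrooxy)methyl)carbonyl in place of hydrogen on an amine nitrogen in a ring. Within the data shown here, no pair of measured compounds differs in just one place, so no measured step is available to guide the expectation. With only the ring-nitrogen substitution separating compound 4 from compound 1, a small step is expected, not beyond the scatter in either direction, with a slight lean upward. Compound 4 is estimated to give 50%, with a range from 35% to 65%. This estimate corresponds to a step of a number 5 percentage points higher from compound 1 to compound 4 (within the scatter) that is expected to stay within the usual scatter.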

Compound 4, a percentage reported as inhibition, in the whole organism at one dose (the size of the read-out at that dose, not a potency): 32%
Compound 4: middle estimate off by 18 percentage points, on the high side, outside the stated range (below it).
By their numbers in this assay, from the lowest: compounds 3, 4, 2 and 1 (each within the scatter of the next, the first and the last beyond it).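

In this assay, among these compounds, the ring nitrogen of compound 1 proves not to be a neutral place for substitution: ((nitrooxy)methyl)carbonyl in place of hydrogen on this amine nitrogen gives a number 13 percentage points lower from compound 1 to compound 4 (beyond the scatter), the first step that changes a single place. The hydrogen on that nitrogen can thus be replaced with inhibition still read, compound 4 giving 32%, but this one change lowers the number instead of raising it. Nothing measured here bears on why the number falls.

The compounds shown leave open whether the fall goes with the nitrooxy end of the group or with the carbonyl on the nitrogen alone, which a plain acetyl group at the same place would help separate. They also leave open how a longer chain between the carbonyl and the nitrooxy end would read.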